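The compounds below may be only part of what the source reports. "The series", "measured", "known", "first", "only" and "open" are said of these compounds alone.

In a functional assay on HEK293 cells for agonist activity at Neuronal acetylcholine receptor; alpha3/beta4 (Homo sapiens), read by FLIPR (a lower number here means that less compound is needed, a higher number that more compound is needed for the effect), compound 1 `Cc1cc(N2CC[C@H]3CN[C@H]3C2)cnc1Cl` gives 7.2 nM, compound 2 `COc1cc(N2C[C@@H]3CCNC[C@@H]32)cnc1Br` gives 2980 nM and compound 3 `COc1cc(N2C[C@H]3CCNC[C@H]32)cnc1Br` gives 202 nM. Compound 3 thus stands second highest of the three numbers; its nearest neighbour is compound 2, and compound 1 lies furthest from it. Compounds 2 and 3 share all atoms and bonds, and the step of a 15-fold lower number from compound 2 to compound 3 (1.17 log units; beyond the scatter) rests on the fact that compounds 2 and 3 differ only in the configuration as drawn alone.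

Compound 4 `NC(=O)c1cc(N2C[C@H]3CCNC[C@H]32)cnc1Br` is reached from compound 3 by the change (carbamoyl in place of methoxy on an aromatic carbon). Within the data shown here, none of the measured steps touches this position, and no other compound carries a carbamoyl group, so nothing measured bears directly on the step; the only step seen, from compound 2 to compound 3, concerns configuration and was large. With no guide from the data, a modest change in either direction is expected, and the estimate stays close to compound 3 with a wide range. For compound 4 the expected value in this assay is 400 nM, with a range from 80 nM to 2000 nM. The expected step is a 2.0-fold higher number from compound 3 to compound 4 (0.30 log units; within the scatter).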

Compound 4, half-maximal effective concentration: 7460 nM
Compound 4: the middle estimate sits 19-fold (1.27 log units) below what was measured; the measured number lies above the stated range.
By their numbers in this assay, from the lowest: compound 1; then compound 3; then compound 2; then compound 4.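

Carbamoyl in place of methoxy on this aromatic carbon, ortho to the bromo group and two atoms from the ring nitrogen, gives in this assay a 37-fold higher number from compound 3 to compound 4 (1.57 log units; beyond the scatter) and thus shows that this position is not indifferent to what it carries. Among these compounds, no earlier step touched this place, so this is the first sign that a change here can move the number strongly, and it moves it towards more compound being needed. Nothing at hand explains why this exchange has so large an effect.

On these data alone, only methoxy and carbamoyl stand at this place, so it remains open whether the rise is particular to carbamoyl or would also come with a carboxylic acid, a nitrile or an ethoxy group. Also open, as far as these compounds go, is whether the same exchange would act alike in the mirror-image configuration of compound 2 or on the core of compound 1.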